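Replacing 3,5-difluorophenyl with thiophen-3-yl on the carbonyl

The compounds below may be only part of what the source reports. "The series", "measured", "known", "first", "only" and "open" are said of these compounds alone.

Measured in a functional assay on A2780 cells (Homo sapiens) for antiproliferative activity, read by fluorescence, with a stated time of 72 h; on this read-out higher numbers stand for weaker inhibition and lower numbers for stronger inhibition:
Compound 1 `CN1CCC(C(=O)N2Cc3c(NC(=O)C4CC4)n[nH]c3C2(C)C)CC1`: 1420 nM
Compound 2 `CN1CCC(C(=O)N2Cc3c(NC(=O)C4CCC4)n[nH]c3C2(C)C)CC1`: 140 nM
Compound 3 `CN1CCC(C(=O)N2Cc3c(NC(=O)c4cc(F)cc(F)c4)n[nH]c3C2(C)C)CC1`: 130 nM

These compounds share one core and differ only in the group on a carbonyl carbon. Compound 3 stands at 130 nM, level with compound 2. The data show a 1.1-fold lower number from compound 2 to compound 3 (0.03 log units; within the scatter), so the two cannot be told apart. Compound 1 lies far off, with a 10-fold lower number from compound 1 to compound 2 (1.01 log units; beyond the scatter) and an 11-fold lower number from compound 1 to compound 3 (1.04 log units; beyond the scatter).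

The next structure is compound 4 `CN1CCC(C(=O)N2Cc3c(NC(=O)c4ccsc4)n[nH]c3C2(C)C)CC1`, with thiophen-3-yl in place of 3,5-difluorophenyl on a carbonyl carbon. Among the measured compounds shown here, no measured step makes this exact swap, so the guidance is indirect. Two of the three groups tried, cyclobutyl and 3,5-difluorophenyl, gave matching numbers, and only cyclopropyl stands apart. Compound 4 keeps an aromatic ring on the carbonyl carbon, as compound 3 does at 130 nM, so no step beyond the scatter is expected in this assay. A slightly higher number seems likelier than a lower one, and the large steps from compound 1 warn that this position can matter. The expected step is a 1.5-fold higher number from compound 3 to compound 4 (0.16 log units; within the scatter). For compound 4 the estimated value is 190 nM, within an expected range of 60 nM to 600 nM.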

Compound 4, half-maximal inhibitory concentration: 140 nM
Estimate against measurement, compound 4: 1.4-fold (0.13 log units) above, and the stated range covers the measured number.
By their numbers in this assay, from the lowest: compounds 3, 2 and 4 (each within the scatter of the next); then compound 1.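

Exchanging 3,5-difluorophenyl for thiophen-3-yl on the carbonyl carbon replaces a six-membered aromatic ring of carbon only with a five-membered aromatic ring holding sulfur, yet this assay shows a 1.1-fold higher number from compound 3 to compound 4 (0.03 log units; within the scatter) and no change at the digits printed from compound 2 to compound 4 (within the scatter) as well. Compounds 2, 3 and 4 therefore sit level despite carrying cyclobutyl, 3,5-difluorophenyl and thiophen-3-yl, and the fluorine atoms of compound 3 are not needed to reach that level, while the one exception remains the cyclopropyl group of compound 1, with a 10-fold lower number from compound 1 to compound 4 (1.01 log units; beyond the scatter) as a large step. Nothing measured here explains why these three groups match or why cyclopropyl stands apart.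

From the compounds shown here alone, it remains open whether the same level holds for cyclopentyl, for unsubstituted phenyl or for thiophen-2-yl, and whether a ring bearing an amine or a carboxylic acid would fit this position equally well. Going by these compounds, it also remains open whether the match among compounds 2, 3 and 4 would persist on cell lines other than the one in this assay.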